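Aromatic substituent exchange and acid dissociation in the oxime amide series

A few compounds are considered here, and "the series" means these few. Any claim that something is new, unique, unknown or untested is made for them only; others in the source may bear on it.

Measured compounds:
compound 1, `N#C/C(=N\O)C(=O)Nc1ccc(F)cc1`: 5.01
compound 2, `N#C/C(=N\O)C(=O)Nc1ccccc1`: 5.12
compound 3, `COc1ccc(NC(=O)/C(C#N)=N/O)cc1`: 5.08

All three numbers come from a physicochemical assay for acid dissociation, using potentiometric titration. They sit in a narrow band: compound 3 is separated from compound 2 by a number 0.04 log units lower from compound 2 to compound 3 (within the scatter) and from compound 1 by a number 0.07 log units higher from compound 1 to compound 3 (within the scatter), so no ordering among the three can be read from this assay. The remaining pair behaves the same way, with a number 0.11 log units higher from compound 1 to compound 2 (within the scatter).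

The next compound is compound 4, `N#C/C(=N\O)C(=O)Nc1ccc(-c2ccccc2)cc1`. Relative to compound 3 the change is phenyl in place of methoxy on an aromatic carbon. Every measured step in the series concerns the same aromatic carbon: fluoro to hydrogen, fluoro to methoxy and hydrogen to methoxy, and each stayed within the scatter of this assay. Among the compounds with values here, those three steps are the only guide available, and none of them moved the acid dissociation constant in a detectable way. The phenyl group is larger than any group tried so far, so the guide is not a close one, but nothing measured points to a shift in either direction. Compound 4 is therefore expected to give 5.08, with a range of 4.8 to 5.36, an expected step of no change at the digits printed from compound 3 to compound 4 (within the scatter) that stays within the scatter.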

Compound 4, acid dissociation constant: 5.03
Compound 4: middle estimate off by 0.05 log units, on the high side; the measured number falls inside the stated range.
By their numbers in this assay, from the lowest: compounds 1, 4, 3 and 2 (each within the scatter of the next).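

In this assay, phenyl at this aromatic carbon gives steps that all stay within the scatter: a number 0.05 log units lower from compound 3 to compound 4 (within the scatter), a number 0.09 log units lower from compound 2 to compound 4 (within the scatter) and a number 0.02 log units higher from compound 1 to compound 4 (within the scatter). The earlier compounds shown here covered only fluoro, hydrogen and methoxy, so the series now includes a group of 6 heavy atoms with one six-membered aromatic ring of carbon only, and still no ordering of the four compounds can be read from this assay. Nothing available bears on the reason for this result.

From the compounds shown here alone, whether an amine, a carboxylic acid or a nitro group on the same aromatic carbon would also stay within the scatter remains open. All four compounds differ at this one aromatic carbon, so the observation applies only to them and leaves open what an exchange elsewhere on the shared core would do to this assay.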